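Chloro for Methoxy on a Subnanomolar Receptor Ligand

The compounds below may be only part of what the source reports. "The series", "measured", "known", "first", "only" and "open" are said of these compounds alone.

Of the compounds shown here, three have been measured in an assay on cell membranes for displacement of a labelled ligand from Neuronal acetylcholine receptor; alpha4/beta2 (Rattus norvegicus); on this read-out higher numbers stand for weaker inhibition and lower numbers for stronger inhibition. Compound 1 `Clc1ccc(Nc2ccc(N3CC4CC(C3)N4)nn2)cc1Cl` gives 516 nM, and compound 3 `CN(c1ccccc1)c1ccc(N2CC3CC(C2)N3)nn1` gives 1430 nM. Compound 2 `COc1ccc(Nc2cncc(N3CC4CC(C3)N4)c2)cc1` stands apart: in this assay compound 2 gives 0.0598 nM, the lowest of the three numbers, and its distance from both compound 1 and compound 3 lies well beyond the scatter. Compound 1 and compound 3 share a core that differs from that of compound 2, so their numbers say nothing direct about the change considered here.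

The unmeasured compound 4 `Clc1ccc(Nc2cncc(N3CC4CC(C3)N4)c2)cc1` keeps the core of compound 2 and differs only in one place: chloro in place of methoxy on an aromatic carbon. Within the data shown here, no measured pair isolates this exchange. Compound 4 is therefore expected to remain close to compound 2, with a step of a 2.5-fold higher number from compound 2 to compound 4 (0.40 log units; beyond the scatter) toward a somewhat higher number that may not exceed the scatter. For compound 4 the estimate in this assay is 0.15 nM, within a range from 0.03 nM to 0.8 nM.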

Compound 4, inhibition constant: 0.118 nM
Beside the measured number, compound 4's estimate is 1.3-fold (0.10 log units) above it; low and high end bracket the measured number.
By their numbers in this assay, from the lowest: compounds 2 and 4 (each within the scatter of the next); then compound 1; then compound 3.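

In this assay, among these compounds, the exchange of methoxy for chloro on an aromatic carbon para to a large group gives a 2.0-fold higher number from compound 2 to compound 4 (0.30 log units; within the scatter), and this is the first pair here to isolate that change. At this position on the core of compound 2, then, a methoxy group with one hydrogen-bond acceptor and a chloro group with none give numbers that the assay cannot separate. Nothing at hand gives a measured basis for this result.

The compounds shown leave open how this position responds to groups of another kind, such as an amine, a carboxylic acid or a longer alkyl chain. They also leave open whether the same exchange would read alike on the core shared by compound 1 and compound 3.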